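Amide side-chain swaps at the shared core

This account rests on a few compounds, and the source may have more. Where it says the series, first, only, none or still open, it means among the compounds named here.

Three amides on the shared core have been measured. In an assay on HEK293 cells for displacement of a labelled ligand from Melanocortin receptor 4 (Homo sapiens) (a higher number here means a weaker inhibitor, a lower number a stronger inhibitor), compound 1 `CC(C)C[C@H](N)c1cc(C(F)(F)F)ccc1N1CCN(C(=O)CNc2ccccc2)CC1` gives 3600 nM, compound 2 `CC(C)C[C@H](N)c1cc(C(F)(F)F)ccc1N1CCN(C(=O)CCC2CCCCC2)CC1` gives 5700 nM, and compound 3 `CC(C)C[C@H](N)c1cc(C(F)(F)F)ccc1N1CCN(C(=O)CC(C)C(=O)c2ccc(Cl)cc2)CC1` gives 1100 nM, the lowest number of the three: a 3.3-fold lower number from compound 1 to compound 3 (0.51 log units; beyond the scatter) and a 5.2-fold lower number from compound 2 to compound 3 (0.71 log units; beyond the scatter), while a 1.6-fold higher number from compound 1 to compound 2 (0.20 log units; within the scatter). Compound 4 `Cc1ccc(OCC(=O)N2CCN(c3ccc(C(F)(F)F)cc3[C@@H](N)CC(C)C)CC2)c(C)c1` carries 2,4-dimethylphenoxy in place of 1-((4-chlorophenyl)carbonyl)ethyl on a saturated chain carbon bound to a carbonyl carbon. Both steps that bear on this position point the same way: leaving 1-((4-chlorophenyl)carbonyl)ethyl for another group has so far meant a modestly higher number, so compound 4 is expected to move back toward compounds 1 and 2 in this assay. The expected step is a 2.3-fold higher number from compound 3 to compound 4 (0.36 log units; beyond the scatter). Compound 4 is expected to give about 2500 nM, between 900 nM and 7000 nM.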

Compound 4, inhibition constant: 4000 nM
Compound 4: middle estimate off by 1.6-fold (0.20 log units), on the low side; the range from low to high includes it.
By their numbers in this assay, from the lowest: compound 3; then compounds 1, 4 and 2 (each within the scatter of the next).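

In this assay, 2,4-dimethylphenoxy is a third group that fails to match 1-((4-chlorophenyl)carbonyl)ethyl, with a 3.6-fold higher number from compound 3 to compound 4 (0.56 log units; beyond the scatter), yet it stays level with the other two groups, with a 1.4-fold lower number from compound 2 to compound 4 (0.15 log units; within the scatter) and a 1.1-fold higher number from compound 1 to compound 4 (0.05 log units; within the scatter). The anilino, cyclohexylmethyl and 2,4-dimethylphenoxy amides thus form one group, with only compound 3 apart, and an aromatic ring alone does not set compound 3 apart, since compounds 1 and 4 also carry one. No supporting data explain this gap. Going by these compounds, it remains open whether the carbonyl, the chlorine or the methyl branch of compound 3 accounts for the difference; a 4-chlorophenoxy group would help separate these.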